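Ester variation at the acyloxy carbon of a lactone core

The source may report more compounds than this note shows. Statements on the series, on what has been measured and on what is new or still open speak of the compounds shown alone.

Compound 2 `CC(=O)[C@@]1(C)C(=O)O[C@@H](OC(=O)C(C)(C)C)[C@H]1C` gives 2000 nM in a functional assay on B16 cells (Mus musculus) for cytotoxicity, read by MTT assay; a higher number here means a weaker inhibitor, a lower number a stronger inhibitor; compound 1 `CC(=O)O[C@@H]1OC(=O)[C@](C)(C(C)=O)[C@@H]1C` gives 4000 nM there, and the step of a 2.0-fold lower number from compound 1 to compound 2 (0.30 log units; within the scatter) sits within the scatter, so compound 2 does not stand apart from compound 1. Compound 3 `CC(=O)[C@@]1(C)C(=O)O[C@@H](OC(=O)c2ccccc2)[C@H]1C` carries the change (phenyl in place of tert-butyl on a carbonyl carbon). Within the data shown here, the only measured step at this position, a 2.0-fold lower number from compound 1 to compound 2 (0.30 log units; within the scatter), was within the scatter, and no measured step involves a phenyl, so no step beyond the scatter is expected for no change at the digits printed from compound 2 to compound 3 (within the scatter). Compound 3 is therefore estimated at 2000 nM, with a range from 700 nM to 6000 nM.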

Compound 3, half-maximal inhibitory concentration: 1000 nM
Beside the measured number, compound 3's estimate is 2.0-fold (0.30 log units) above it; measured number inside the range.
By their numbers in this assay, from the lowest: compounds 3, 2 and 1 (each within the scatter of the next, the first and the last beyond it).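

In this assay, among these compounds, the phenyl ester gives a 2.0-fold lower number from compound 2 to compound 3 (0.30 log units; within the scatter) and so does not separate from the tert-butyl ester, yet phenyl in place of methyl gives a 4.0-fold lower number from compound 1 to compound 3 (0.60 log units; beyond the scatter) as the first step at this position beyond the scatter, though only a modest one. The acyl group on this carbonyl carbon can therefore shift the number a little, with methyl and phenyl at the two ends of this short series. Nothing at hand explains this result. Still open, going by these compounds, is whether a phenyl carrying an amine or a carboxylic acid, or a longer chain on the same carbonyl carbon, would take the number further.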